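Series notes: aryl swap on the pyridazinone nitrogen

The compounds below may be only part of what the source reports. "The series", "measured", "known", "first", "only" and "open" are said of these compounds alone.

Measured so far in a functional assay on PC-3 cells (Homo sapiens) for cytotoxicity, read by MTT assay, with a stated time of 72 h; a lower number here means a stronger inhibitor, a higher number a weaker inhibitor:
compound 1 `Cn1ccc2c(Oc3ccc(NC(=O)c4nn(-c5ccc(Br)cc5)ccc4=O)cc3)ccnc21` gives 23000 nM
compound 2 `Cc1cc(=O)n(-c2ccc(Br)cc2F)nc1C(=O)Nc1ccc(Oc2ncnc3[nH]ccc23)cc1` gives 2730 nM
compound 3 `Cc1cc(=O)n(-c2ccc(Br)cc2F)nc1C(=O)Nc1ccc(Oc2ncnc3c2ccn3C)cc1` gives 18800 nM

Compound 3 stands second highest of the three numbers. Within the data shown here, its nearest neighbour is compound 1, whose value lies within the scatter of that of compound 3; the only value clearly apart is that of compound 2. Among the measured compounds shown here, the single step measured within one place, a 6.9-fold higher number from compound 2 to compound 3 (0.84 log units; beyond the scatter), concerns the methyl on the aromatic nitrogen of the shared core and does not touch the aryl group on the pyridazinone nitrogen.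

Compound 4 `Cc1cc(=O)n(-c2ccccc2Cl)nc1C(=O)Nc1ccc(Oc2ncnc3c2ccn3C)cc1` differs from compound 3 by 2-chlorophenyl in place of 4-bromo-2-fluorophenyl on an aromatic nitrogen. For the measured compounds named here, no measured step bears on this change; compound 1 carries a different aryl at that position, but it also differs in the core, so its value does not isolate the aryl swap. With nothing to point either way, no step beyond the scatter is expected, and the number for compound 4 is estimated near that of compound 3: a 1.2-fold lower number from compound 3 to compound 4 (0.07 log units; within the scatter). The estimate for compound 4 in this assay is 16000 nM, with a range from 5000 nM to 50000 nM.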

Compound 4, half-maximal inhibitory concentration: 16400 nM
Compound 4: middle estimate off by 1.0-fold (0.01 log units), on the low side, and the stated range covers the measured number.
By their numbers in this assay, from the lowest: compound 2; then compounds 4, 3 and 1 (each within the scatter of the next).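

In this assay the aryl swap on the aromatic nitrogen now has a direct reading: a 1.1-fold lower number from compound 3 to compound 4 (0.06 log units; within the scatter) is a step within the scatter, so 2-chlorophenyl and 4-bromo-2-fluorophenyl cannot be told apart at this position on the shared core of these two compounds. The exchange removes the bromine and the fluorine and brings in a chlorine without a step beyond the scatter, a finding that rests on this single pair. Nothing at hand speaks to the reason for this result.

As far as these compounds go, whether the same holds on the core of compound 2, which lacks the methyl on the aromatic nitrogen, remains open. Also open, from the compounds shown here alone, is how an aryl group carrying an amine or a carboxylic acid, or a plain alkyl chain in place of the aryl group, would read at this position in this assay.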